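Two triazole amide pairs and one shared exchange

The source may hold more compounds than are shown below. What is called first, only, known or untested is meant among the compounds shown, and "the series" means these compounds.

Compound 1 `CCOC(=O)Cn1cc(CNC(=O)c2cn(Cc3ccccc3)nn2)nn1` and compound 2 `CC(=O)OCCn1cc(CNC(=O)c2cn(Cc3ccccc3)nn2)nn1` are built on one core, while compound 3 `CCOC(=O)Cn1cc(C(=O)Nc2cccc(-c3cn(CC(=O)OCC)nn3)c2)nn1` and compound 4 `CCOC(=O)Cn1cc(C(=O)Nc2cccc(-c3cn(CCOC(C)=O)nn3)c2)nn1` are built on another; how the two cores differ is not broken down here. In a functional assay on B16 cells (Mus musculus) for cytotoxicity, read by MTT assay, with a stated time of 48 h (on this read-out lower numbers stand for stronger inhibition and higher numbers for weaker inhibition), compound 1 gives 35000 nM. In this assay compound 2 gives 28000 nM. The change that separates these two is acetoxymethyl in place of ethoxycarbonyl on a saturated chain carbon bound to an aromatic nitrogen, and on this assay it made a 1.3-fold lower number from compound 1 to compound 2 (0.10 log units; within the scatter), so the two values show no difference that can be trusted.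

For compound 3 this assay reports only a limit and no number, > 100000 nM. This is the limit at which (the limit of > 100000 nM in this assay, at which 1 of the 3 values shown sits).

Among the compounds with values here, compound 4 differs from compound 3 by acetoxymethyl in place of ethoxycarbonyl on a saturated chain carbon bound to an aromatic nitrogen, which is the same change as the one from compound 1 to compound 2, made at the same kind of place. The expectation for compound 4 therefore rests on two things: compound 3 sits at the limit > 100000 nM, and the same exchange gave only a 1.3-fold lower number from compound 1 to compound 2 (0.10 log units; within the scatter), a step within the scatter. Compound 4 is thus expected to stay at or around the limit as well, with an expected step that the limit leaves unreadable from compound 3 to compound 4. Compound 4 is estimated at 110000 nM, with a range from 45000 nM to 300000 nM, and a limit rather than a number is the most likely outcome for it.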

Compound 4, half-maximal inhibitory concentration: > 100000 nM
Compound 4: no number, only a limit; the forecaster's own chance of this, stated with the estimate: 75%; the middle value is on the limit's open side.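

In this assay compound 4 gives only a limit and not a number, > 100000 nM. Within the data shown here, compound 3 also stands at a limit, so no step from compound 3 to compound 4 can be read. Both compounds share one reading: the limit of > 100000 nM in this assay, at which 2 of the 4 values shown sit.

As far as these compounds go, what stays open is how far compound 3 and compound 4 lie beyond that limit, and so whether exchanging ethoxycarbonyl for acetoxymethyl on their core shifts the read-out at all.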